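The source may hold more compounds than are shown below. What is called first, only, known or untested is meant among the compounds shown, and "the series" means these compounds.

Working notes on the series. Compound 1 `Cc1ccccc1-c1cc(C(=O)NCCCN2CCCC2)ccn1` gives 8800 nM in an assay on isolated protein for inhibition of N-lysine methyltransferase SMYD2 (Homo sapiens); a lower number here means a stronger inhibitor, a higher number a weaker inhibitor. Among the measured compounds shown here, compound 2 `COc1cc(C(=O)NCCCN2CCCC2)cc(-c2ccccc2C)n1` gives 9900 nM in this assay, the highest of the two numbers so far, the step of a 1.1-fold higher number from compound 1 to compound 2 (0.05 log units; within the scatter) staying within the scatter. Compound 3 `CNc1cc(C(=O)NCCCN2CCCC2)cc(-c2ccccc2C)n1` carries methylamino in place of methoxy on an aromatic carbon. For the measured compounds named here, only that one measured step bears on this change, and it was small, so no shift beyond the scatter is expected here; the expected step is a 1.1-fold lower number from compound 2 to compound 3 (0.04 log units; within the scatter). Compound 3 is estimated at 9000 nM, with a range from 3000 nM to 27000 nM.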

Compound 3, half-maximal inhibitory concentration: 17700 nM
For compound 3 the middle estimate is 2.0-fold (0.29 log units) below the measured one, within the range that was stated.
By their numbers in this assay, from the lowest: compounds 1, 2 and 3 (each within the scatter of the next).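

In this assay, the change to methylamino adds a hydrogen-bond donor on the aromatic carbon next to the ring nitrogen and gives a 1.8-fold higher number from compound 2 to compound 3 (0.25 log units; within the scatter), while the comparison with hydrogen at that carbon gives a 2.0-fold higher number from compound 1 to compound 3 (0.30 log units; within the scatter). At this position, then, neither methoxy nor methylamino separates from hydrogen, and a donor at this carbon leaves the number within the scatter. No supporting data bear on this result.

As far as these compounds go, whether a primary amine, a carboxylic acid or a longer alkoxy chain at this carbon would move the number beyond the scatter remains open.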